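The source may report more compounds than this note shows. Statements on the series, on what has been measured and on what is new or still open speak of the compounds shown alone.

Of the compounds shown here, three of this set have been measured in a functional assay on A549 cells (Homo sapiens) for cytotoxicity, read by sulforhodamine B assay, with a stated time of 72 h; on this read-out lower numbers stand for stronger inhibition and higher numbers for weaker inhibition. Compound 1, `COC(=O)C1=C(c2cc(Br)c(O)c(Br)c2)C(=O)C(c2cc(Br)c(O)c(Br)c2)(c2cc(Br)c(O)c(Br)c2)C1=O`, gives only a limit of the assay, > 10000 nM. Compound 2, `COc1ccc(C[C@@]2(O)OC(=O)C([C@@H](O)c3cc(Br)c(OC)c(Br)c3)=C2c2cc(Br)c(O)c(Br)c2)cc1Br`, likewise gives only a limit, > 10000 nM. Compound 3, `COC(=O)C1=C(c2cc(Br)c(O)c(Br)c2)C(=O)[C@](c2ccc(O)c(Br)c2)(c2cc(Br)c(O)c(Br)c2)C1=O`, also returns only a limit, > 10000 nM, so no number marks where it stands; its value joins the others at the limit of > 10000 nM in this assay, at which 3 of the 3 values shown sit, with nothing measurable to separate the three.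

Compound 4, `COC(=O)C1=C(c2ccc(O)c(Br)c2)C(=O)[C@](c2ccc(O)c(Br)c2)(c2cc(Br)c(O)c(Br)c2)C1=O`, differs from compound 3 by one change: hydrogen in place of bromo on an aromatic carbon. Among the measured compounds shown here, no measured step covers this change. For the measured compounds named here, since every value so far is a limit, no step beyond the scatter is expected in this assay; compound 4 is expected to remain near the limit, a step that the limit leaves unreadable from compound 3 to compound 4. Compound 4 is therefore estimated at 15000 nM, within 5000 nM to 50000 nM.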

Compound 4, half-maximal inhibitory concentration: > 10000 nM
Compound 4 ended at the assay's limit; the forecaster's own chance of this, stated with the estimate: 85%; the middle value is on the limit's open side.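

Compound 3 and compound 4 both rest at a limit, so no step can be read between them: the limit of > 10000 nM in this assay, at which 4 of the 4 values shown sit. The compounds shown leave open whether hydrogen in place of bromo changes the read-out at all, and which structure would give a measurable value.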